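The source may hold more compounds than are shown below. What is called first, only, known or untested is meant among the compounds shown, and "the series" means these compounds.

In a functional assay on MGC-803 cells (Homo sapiens) for antiproliferative activity, read by MTT assay, with a stated time of 48 h (on this read-out higher numbers stand for weaker inhibition and lower numbers for stronger inhibition), compound 3 `COc1ccc(CN(C(=O)CSc2nc3cc(Br)ccc3s2)c2cc(OC)c(OC)c(OC)c2)cc1O` gives 372 nM, the higher of the two numbers recorded; its nearest neighbour is compound 1 `COc1ccc2nc(SCC(=O)N(Cc3ccc(OC)c(O)c3)c3cc(OC)c(OC)c(OC)c3)sc2c1`, which gives 71 nM. Compound 2 `COc1cc(N(Cc2ccc(F)cc2)C(=O)CSc2nc3ccccc3s2)cc(OC)c1OC` is known only as a limit, > 80000 nM. Among the compounds with values here, the single step with a number at both ends, a 5.2-fold higher number from compound 1 to compound 3 (0.72 log units; beyond the scatter), shows that exchanging the group on the sulfur can move this read-out beyond the scatter. Compound 4 `COc1ccc(CN(C(=O)CSc2nc3c(C)cccc3s2)c2cc(OC)c(OC)c(OC)c2)cc1O` keeps the core of compound 3 and alters that same group: a group of 10 heavy atoms (8 carbon, 1 nitrogen, 1 sulfur; one five-membered aromatic ring with 2 hetero atoms, one six-membered aromatic ring of carbon only) in place of a group of 10 heavy atoms (7 carbon, 1 nitrogen, 1 sulfur, 1 bromine; one five-membered aromatic ring with 2 hetero atoms, one six-membered aromatic ring of carbon only), on a sulfur. Within the data shown here, no measured step covers this exact exchange; the expectation therefore rests on the size of the step from compound 1 to compound 3 and allows a modest shift in either direction. Compound 4 is expected to give 200 nM, within 60 nM to 700 nM. That estimate would mean a step of a 1.9-fold lower number from compound 3 to compound 4 (0.27 log units; within the scatter).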

Compound 4, half-maximal inhibitory concentration: 493 nM
The estimate for compound 4 lay 2.5-fold (0.39 log units) below the measured number; the measured number falls inside the stated range.
By their numbers in this assay, from the lowest: compound 1; then compounds 3 and 4 (each within the scatter of the next). At a limit, above all of these: compound 2.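

In this assay, 4-methyl-1,3-benzothiazol-2-yl on the sulfur in place of the bromine-bearing group gives a 1.3-fold higher number from compound 3 to compound 4 (0.12 log units; within the scatter), so these two groups cannot be told apart here. Exchanging 6-methoxy-1,3-benzothiazol-2-yl for the same 4-methyl-1,3-benzothiazol-2-yl gives a 6.9-fold higher number from compound 1 to compound 4 (0.84 log units; beyond the scatter), so a second replacement of that group also ends beyond the scatter on the higher side. Nothing given here accounts for these steps. Still open, on these data alone, is whether an ethoxy, a hydroxyl or an amine in place of the methoxy of 6-methoxy-1,3-benzothiazol-2-yl would hold the number of compound 1.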